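Aryl Swap on a Triazole-Bearing Arm Leaves Potency Unchanged

The source may report more compounds than this note shows. Statements on the series, on what has been measured and on what is new or still open speak of the compounds shown alone.

The measured compounds in a functional assay on MCF7 cells (Homo sapiens) for antiproliferative activity, read by MTT assay, with a stated time of 48 h (on this read-out higher numbers stand for weaker inhibition and lower numbers for stronger inhibition), are these. Compound 1 `N#CC1=C(N)Oc2c(N)cc3nc4ccccc4nc3c2C12C(=O)N(Cc1cnnn1-c1ccc(F)cc1)c1ccccc12` gives > 50000 nM, which is a limit of the assay. Compound 2 `N#CC1=C(N)Oc2c(N)cc3nc4ccccc4nc3c2C12C(=O)N(Cc1cnnn1-c1ccccc1Cl)c1ccccc12` gives 34400 nM. Compound 3 `N#CC1=C(N)Oc2c(N)cc3nc4ccccc4nc3c2C12C(=O)N(Cc1cnnn1-c1cccc(C(F)(F)F)c1)c1ccccc12` gives 31600 nM.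

Compound 3 holds the lowest of the two numbers shown, and its nearest neighbour is compound 2, within the scatter. Compound 1 sits at the assay limit (the limit of > 50000 nM in this assay, at which 1 of the 3 values shown sits). The step to compound 4 `N#CC1=C(N)Oc2c(N)cc3nc4ccccc4nc3c2C12C(=O)N(Cc1cnnn1-c1ccc([N+](=O)[O-])cc1)c1ccccc12` changes the aryl group on an aromatic nitrogen of the five-membered aromatic ring with 3 nitrogen: 4-nitrophenyl in place of 3-(trifluoromethyl)phenyl on an aromatic nitrogen.

Three measured steps change the same group. The step of an at least 1.4-fold lower number from compound 1 to compound 2 (0.16 log units; that floor lies within the scatter) and the step of an at least 1.5-fold lower number from compound 1 to compound 3 (0.19 log units; that floor lies within the scatter) start from a limit, so their floors lie within the scatter. The step of a 1.1-fold lower number from compound 2 to compound 3 (0.04 log units; within the scatter) lies within the scatter as well. None of the three aryl groups tried so far separates from the others beyond the scatter. For compound 4, accordingly, no step beyond the scatter is expected in this assay, and the expected step is a 1.0-fold higher number from compound 3 to compound 4 (0.01 log units; within the scatter). Compound 4 is therefore estimated at 32000 nM, with a range from 12000 nM to 85000 nM, and a real chance that only a limit is reported.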

Compound 4, half-maximal inhibitory concentration: > 50000 nM
Compound 4 gave a limit, no number; the forecaster's own chance of this, stated with the estimate: 30%; middle value at least 1.5-fold (0.19 log units) from the limit.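

In this assay compound 4 returns only a limit, > 50000 nM. The step of an at least 1.5-fold higher number from compound 3 to compound 4 (0.19 log units; that floor lies within the scatter) and the step of an at least 1.4-fold higher number from compound 2 to compound 4 (0.16 log units; that floor lies within the scatter) do not set the 4-nitrophenyl group apart from the other two aryl groups, yet a second aryl group now ends at the limit: the limit of > 50000 nM in this assay, at which 2 of the 4 values shown sit. The two limits fall on the 4-fluorophenyl and 4-nitrophenyl groups, while the 2-chlorophenyl and 3-(trifluoromethyl)phenyl groups of compound 2 and compound 3 give numbers, though that split rests only on these four compounds and on floors within the scatter, and the step between compound 1 and compound 4 cannot be read.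

The compounds shown leave open whether an amine, a carboxylic acid or a methoxy group on the phenyl ring, or a plain phenyl group, on this same aromatic nitrogen gives a number or a limit. They also leave open whether any aryl group at this place can move the read-out beyond the scatter, in either direction, from the values seen so far.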